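This account rests on a few compounds, and the source may have more. Where it says the series, first, only, none or still open, it means among the compounds named here.

Measured so far:
compound 1 `COc1ccc(-c2cn(-c3ccc(Oc4ccccc4)cc3)nn2)cc1` — > 100 nM
compound 2 `COc1ccc(-c2cn(-c3ccc(Oc4ccccc4)cc3)nn2)cc1O` — > 10000 nM

In a functional assay on MDA-MB-231 cells (Homo sapiens) for cytotoxicity, read by MTT assay (a higher number here means a weaker inhibitor, a lower number a stronger inhibitor), compound 1 gives only a limit, > 100 nM (the limit of > 100 nM in this assay, at which 1 of the 2 values shown sits). Compound 2 also gives only a limit, > 10000 nM (the limit of > 10000 nM in this assay, at which 1 of the 2 values shown sits). Going by the values given here, the one measured step, a step that the two limits leave unreadable from compound 1 to compound 2, is therefore unreadable in size. Compound 3 `Nc1ccc(-c2cn(-c3ccc(Oc4ccccc4)cc3)nn2)cc1` differs from compound 2 by 4-aminophenyl in place of 3-hydroxy-4-methoxyphenyl on an aromatic carbon. Among the compounds with values here, no measured step bears on this change, so no direction beyond the scatter can be expected in this assay, and a limit is likely again. Compound 3 is expected around 5000 nM, estimated between 500 nM and 50000 nM. The expected step is an at least 2.0-fold lower number from compound 2 to compound 3 (0.30 log units; that floor lies within the scatter).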

Compound 3, half-maximal inhibitory concentration: > 10000 nM
Compound 3 ended at the assay's limit (the forecaster's own chance of this, stated with the estimate: 60%); middle value at least 2.0-fold (0.30 log units) away from the limit.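

No step can be read from compound 1 or compound 2 to compound 3, since all three compounds give only limits: the limit of > 10000 nM in this assay, at which 2 of the 3 values shown sit.

On these data alone, whether 4-aminophenyl or amino in these places changes cytotoxicity remains open.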